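Carboxy to ethoxycarbonyl: one step, one expectation

A few compounds are considered here, and "the series" means these few. Any claim that something is new, unique, unknown or untested is made for them only; others in the source may bear on it.

Measured compounds, with their numbers from a functional assay on a cell-free system (Platelet, plasma, Oryctolagus cuniculus) for inhibition, with a stated time of 5 min, at 37 degrees C; on this read-out lower numbers stand for stronger inhibition and higher numbers for weaker inhibition:
compound 1 `Cc1nc(C)c(C(=O)Oc2ccc(/C=C/C(=O)O)cc2O)nc1C`, 84600 nM;
compound 2 `CCOC(=O)/C=C/c1ccc(OC(=O)c2nc(C)c(C)nc2C)c(O)c1`, 77400 nM;
compound 3 `COc1ccc(/C=C/C(=O)O)cc1OC(=O)c1nc(C)c(C)nc1C`, 41800 nM.

Compound 3 stands at the lowest number of the three. Compound 2 is nearest to it, and that gap is within the scatter; compound 1 is the furthest, and that gap lies beyond the scatter, so compound 3 is separated only from compound 1 by more than the usual variation.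

Compound 4 `CCOC(=O)/C=C/c1ccc(OC)c(OC(=O)c2nc(C)c(C)nc2C)c1` is yet to be measured in this assay. Relative to compound 3 it carries ethyl in place of hydrogen on an oxygen next to a carbonyl group. One measured pair bears directly on this change, and it is the same change on the same position of the chain: a 1.1-fold lower number from compound 1 to compound 2 (0.04 log units; within the scatter). That step stayed within the scatter, so nothing beyond the scatter is expected here either; if anything, a slightly lower number. Compound 4 is therefore expected to give about 38000 nM, with a range from 19000 nM to 76000 nM. The step this estimate means is a 1.1-fold lower number from compound 3 to compound 4 (0.04 log units; within the scatter), which is expected to stay within the scatter.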

Compound 4, half-maximal inhibitory concentration: 143000 nM
The estimate for compound 4 lay 3.8-fold (0.58 log units) below the measured number, outside the stated range (above it).
By their numbers in this assay, from the lowest: compounds 3, 2, 1 and 4 (each within the scatter of the next, the first and the last beyond it).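

In this assay ethyl in place of hydrogen on an oxygen next to a carbonyl group is not silent on every core: the change gives a 3.4-fold higher number from compound 3 to compound 4 (0.53 log units; beyond the scatter) and so weakens inhibition modestly. The pair on the core of compound 1 showed no such cost, and taken alone it gave no hint of one. The outcome of carboxy to ethoxycarbonyl at this position therefore depends on the core that carries it: the same change on two cores in this assay, a 1.1-fold lower number (0.04 log units; within the scatter) from compound 1 to compound 2 and a 3.4-fold higher number (0.53 log units; beyond the scatter) from compound 3 to compound 4, 3.7-fold (0.57 log units) apart, beyond the scatter of two such steps.

Which difference between the two cores decides the outcome stays open, as no compound shown separates it from the ester change itself. As far as these compounds go, whether a methyl ester, a longer chain on the ester oxygen or a primary amide in place of the carboxylic acid follows the same core dependence also stays open.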